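Methyl on the terminal ring: compound 3 from compound 2

The source may hold more compounds than are shown below. What is called first, only, known or untested is meant among the compounds shown, and "the series" means these compounds.

Measured compounds:
compound 1 `COc1cc2c(Oc3ccc(NC(=O)c4nn(-c5ccccc5)c(=O)c5ccccc45)cc3F)ccnc2cc1OCCCN1CCCC1` 530 nM
compound 2 `COc1cc2c(Oc3ccc(NC(=O)c4nn(-c5ccccc5)c(=O)c5ccccc45)cc3F)ccnc2cc1OCCCN1CCCCC1` 590 nM

In a functional assay on MKN-45 cells (Homo sapiens) for cytotoxicity, read by MTT assay, with a stated time of 72 h (on this read-out lower numbers stand for stronger inhibition and higher numbers for weaker inhibition), compound 2 gives the highest of the two numbers shown, and its nearest neighbour is compound 1; the step of a 1.1-fold higher number from compound 1 to compound 2 (0.05 log units; within the scatter) lies within the scatter, so nothing separates them. Compound 3 `COc1cc2c(Oc3ccc(NC(=O)c4nn(-c5ccccc5)c(=O)c5ccccc45)cc3F)ccnc2cc1OCCCN1CCC(C)CC1` differs from compound 2 by methyl in place of hydrogen on a saturated ring carbon. Among the measured compounds shown here, only that one step, at the same chain end, bears on this change, and it was flat. Compound 3 is therefore expected to sit close to compound 2, with the step of a 1.0-fold higher number from compound 2 to compound 3 (0.01 log units; within the scatter) meaning no change beyond the scatter. The estimate for compound 3 is 600 nM, within 250 nM to 1400 nM.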

Compound 3, half-maximal inhibitory concentration: 580 nM
The estimate for compound 3 lay 1.0-fold (0.01 log units) above the measured number; low and high end bracket the measured number.
By their numbers in this assay, from the lowest: compounds 1, 3 and 2 (each within the scatter of the next).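

In this assay the step of a 1.0-fold lower number from compound 2 to compound 3 (0.01 log units; within the scatter) stays within the scatter when methyl replaces hydrogen on a saturated ring carbon, three ring bonds from the ring nitrogen, so this added carbon leaves the number unmoved. The step of a 1.1-fold higher number from compound 1 to compound 3 (0.04 log units; within the scatter) is also within the scatter for 4-methylpiperidin-1-yl in place of pyrrolidin-1-yl, so no two of the three terminal rings can be separated. No supporting measurement bears on this flat result. Open, going by these compounds, is whether a morpholin-4-yl ring, a carboxylic acid on the ring, or a longer chain would move the number beyond the scatter.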